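Lengthening the chain on an already inactive compound

The source may hold more compounds than are shown below. What is called first, only, known or untested is meant among the compounds shown, and "the series" means these compounds.

Measured in a functional assay on DU-145 cells (Homo sapiens) for antiproliferative activity, read by WST assay, with a stated time of 3 days; on this read-out higher numbers stand for weaker inhibition and lower numbers for stronger inhibition:
- compound 1 `CCOc1c(-c2cc(OC)c(OC)c(OC)c2)oc2ccccc2c1=O`: 6200 nM
- compound 2 `CCCCCOc1c(-c2cc(OC)c(OC)c(OC)c2)oc2ccccc2c1=O`: > 50000 nM (a limit of the assay)

Compound 2 stands at > 50000 nM, which is a limit of the assay and not a number. Compound 3 `CCCCCCOc1c(-c2cc(OC)c(OC)c(OC)c2)oc2ccccc2c1=O` differs from it by one small change on the same chain: methyl in place of hydrogen on a saturated chain carbon, five bonds along the chain from an oxygen on an aromatic ring. Among the measured compounds shown here, the only measured step that bears on this, an at least 8.0-fold higher number from compound 1 to compound 2 (0.90 log units; beyond the scatter), also extended that chain, and inhibition became weaker. Further weakening cannot be read past the limit, so no step beyond the scatter is expected in this assay. The expected size is a number no higher from compound 2 to compound 3 (the limit leaves the size open). For compound 3 the estimate is 50000 nM, with an expected range of 25000 nM to 100000 nM.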

Compound 3, half-maximal inhibitory concentration: > 50000 nM
Compound 3: no number, only a limit; the forecaster's own chance of this, stated with the estimate: 80%; the middle value sits exactly at the limit.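

In this assay compound 3 stands at > 50000 nM, which is a limit of the assay and not a number. Butyl in place of hydrogen on the chain of compound 1 gives an at least 8.0-fold higher number from compound 1 to compound 3 (0.90 log units; beyond the scatter), so the weak inhibition does not return when the chain grows past that of compound 2. The step between compound 2 and compound 3 cannot be read because both values are limits: the limit of > 50000 nM in this assay, at which 2 of the 3 values shown sit.

Still open, from the compounds shown here alone, is how a shorter chain, or an amine or a carboxylic acid at the chain end, would behave in this assay.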